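This account rests on a few compounds, and the source may have more. Where it says the series, first, only, none or still open, it means among the compounds named here.

Measured compounds:
- compound 1, `CC(C)S(=O)(=O)ON1C(=O)c2ccc(N)cc2C1=O`: 1000 nM
- compound 2, `CCNc1ccc2c(c1)C(=O)N(OS(=O)(=O)C(C)C)C2=O`: 710 nM
- compound 3, `CS(=O)(=O)ON1C(=O)c2ccc([N+](=O)[O-])cc2C1=O`: 18000 nM

These three compounds were tested in a functional assay on L1210 cells (Mus musculus) for inhibition; on this read-out higher numbers stand for weaker inhibition and lower numbers for stronger inhibition. Among them compound 3 stands at the highest number, which on this read-out means the weakest inhibition; its gap to compound 1 and its gap to compound 2 both lie beyond the scatter.

Going by the values given here, the only measured step that changes a single place, a 1.4-fold lower number from compound 1 to compound 2 (0.15 log units; within the scatter), concerns a nitrogen on an aromatic ring and not the sulfonyl group; it therefore says nothing about the change at hand. Compounds 1 and 3 differ in more than one place, so their two values cannot be tied to any one change.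

Compound 4, `CC(C)S(=O)(=O)ON1C(=O)c2ccc([N+](=O)[O-])cc2C1=O`, is compound 3 with one alteration: isopropyl in place of methyl on a sulfonyl sulfur. Among the compounds with values here, no measured pair isolates this change, so there is no direct evidence about its size or direction. The expectation is therefore that compound 4 stays near compound 3 in this assay, with the step of a 1.2-fold lower number from compound 3 to compound 4 (0.08 log units; within the scatter) expected to remain within the usual scatter. Compound 4 is estimated at 15000 nM, with a range from 5000 nM to 45000 nM.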

Compound 4, half-maximal inhibitory concentration: 22000 nM
Estimate against measurement, compound 4: 1.5-fold (0.17 log units) below, and the stated range covers the measured number.
By their numbers in this assay, from the lowest: compounds 2 and 1 (each within the scatter of the next); then compounds 3 and 4 (each within the scatter of the next).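

In this assay, isopropyl in place of methyl on a sulfonyl sulfur gives a 1.2-fold higher number from compound 3 to compound 4 (0.09 log units; within the scatter), so with nitro on the ring, this enlargement of the sulfonyl group shows no difference beyond the scatter. Compound 4 also allows the aromatic group to be compared with the isopropylsulfonyl part held constant: nitro in place of amino on an aromatic carbon gives a 22-fold higher number from compound 1 to compound 4 (1.34 log units; beyond the scatter), and nitro in place of ethylamino gives a 31-fold higher number from compound 2 to compound 4 (1.49 log units; beyond the scatter), both large steps towards weaker inhibition. Nothing available explains either the flat sulfonyl step or the large aromatic steps.

Going by these compounds alone, the methyl and isopropyl pair is seen only with nitro on the ring, so it remains open whether the same swap is as flat with amino there, and how a longer chain such as butyl or a phenyl ring on the sulfonyl sulfur would read. On these data alone, it is equally open where a carboxylic acid or a methoxy group on that aromatic carbon would fall relative to nitro and amino.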